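A few compounds are considered here, and "the series" means these few. Any claim that something is new, unique, unknown or untested is made for them only; others in the source may bear on it.

Of the compounds shown here, three built on one shared core have been measured in an assay on HEK293 cells for displacement of a labelled ligand from Melanocortin receptor 4 (Homo sapiens); on this read-out higher numbers stand for weaker inhibition and lower numbers for stronger inhibition. Compound 1 `COc1ccc(CCC(=O)N2CCN(c3ccc(C(F)(F)F)cc3[C@@H](N)CC(C)C)CC2)cc1` gives 350 nM. Compound 2 `COc1ccc(OC)c(CCC(=O)N2CCN(c3ccc(C(F)(F)F)cc3[C@@H](N)CC(C)C)CC2)c1` gives 2500 nM. Compound 3 `CC(C)C[C@H](N)c1cc(C(F)(F)F)ccc1N1CCN(C(=O)CCc2cccs2)CC1` gives 4600 nM, the highest of the three numbers: the move reads a 13-fold higher number from compound 1 to compound 3 (1.12 log units; beyond the scatter), while the nearest neighbour is reached by a 1.8-fold higher number from compound 2 to compound 3 (0.26 log units; within the scatter), so compound 3 and compound 2 cannot be told apart on this read-out.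

Compound 4 `CC(C)C[C@H](N)c1cc(C(F)(F)F)ccc1N1CCN(C(=O)CCc2c[nH]c3ccccc23)CC1` differs from compound 3 in one place: 1H-indol-3-yl in place of thiophen-2-yl on a saturated chain carbon, two bonds along the chain from a carbonyl carbon. Every measured step changes the aromatic group at this same position, so all three bear on the question. The step of a 7.1-fold higher number from compound 1 to compound 2 (0.85 log units; beyond the scatter) and the step of a 13-fold higher number from compound 1 to compound 3 (1.12 log units; beyond the scatter) show that swapping this group can shift the number a long way, whereas a 1.8-fold higher number from compound 2 to compound 3 (0.26 log units; within the scatter) shows two quite different groups giving the same result. Going by the values given here, no measured compound carries an indole, so the data give the span of possible outcomes rather than a direction. The expectation for compound 4 is therefore cautious: a number somewhat lower than compound 3, with a wide range, amounting to a 3.1-fold lower number from compound 3 to compound 4 (0.49 log units; beyond the scatter). Compound 4 is estimated at 1500 nM, between 300 nM and 7000 nM.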

Compound 4, inhibition constant: 640 nM
Estimate against measurement, compound 4: 2.3-fold (0.37 log units) above, within the range that was stated.
By their numbers in this assay, from the lowest: compounds 1 and 4 (each within the scatter of the next); then compounds 2 and 3 (each within the scatter of the next).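

In this assay, 1H-indol-3-yl at this position, on a saturated chain carbon two bonds along the chain from a carbonyl carbon, gives a 7.2-fold lower number from compound 3 to compound 4 (0.86 log units; beyond the scatter) and a 3.9-fold lower number from compound 2 to compound 4 (0.59 log units; beyond the scatter), so this group clearly separates from both thiophen-2-yl and 2,5-dimethoxyphenyl. Going by these compounds alone, the remaining comparison reads a 1.8-fold higher number from compound 1 to compound 4 (0.26 log units; within the scatter), so 4-methoxyphenyl is no longer the only group at this position that stands apart from those two, and a group with a quite different ring make-up gives a number that cannot be told from it. The step from thiophen-2-yl to 1H-indol-3-yl adds heavy atoms, a six-membered aromatic ring and a hydrogen-bond donor all at once, and no supporting measurement is available to show which of these changes, if any, accounts for the shift.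

The compounds shown leave open whether the hydrogen-bond donor counts for anything, a question that 1-methyl-1H-indol-3-yl or naphthalen-1-yl at the same position could help to settle. They also leave open how the result depends on the chain itself, for instance whether a longer chain carrying the same 1H-indol-3-yl group would give a similar number.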